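A few compounds are considered here, and "the series" means these few. Any claim that something is new, unique, unknown or untested is made for them only; others in the source may bear on it.

Measured in a functional assay on HL-60 cells (Homo sapiens) for antiproliferative activity, read by MTT assay, with a stated time of 48 h; on this read-out higher numbers stand for weaker inhibition and lower numbers for stronger inhibition:
Compound 1 `N#Cc1nc2c(-c3nc4ccccc4[nH]3)c(N)n(CCO)c2nc1C#N`: > 50000 nM, a limit
Compound 2 `CCCCn1c(N)c(-c2nc3ccccc3[nH]2)c2nc(C#N)c(C#N)nc21`: > 50000 nM, a limit

Compound 2 stands only at a limit, > 50000 nM. Going by the values given here, the series so far offers no number: the limit of > 50000 nM in this assay, at which 2 of the 2 values shown sit. Compound 3 `CCN(CC)CCCCn1c(N)c(-c2nc3ccccc3[nH]2)c2nc(C#N)c(C#N)nc21` carries diethylamino in place of hydrogen on a saturated chain carbon, four bonds along the chain from an aromatic nitrogen. Among the compounds with values here, the only measured step, a step that the two limits leave unreadable from compound 1 to compound 2, gives no size to carry over, so the expectation is loose and compound 3 may also report only a limit. A modest move toward stronger inhibition in this assay is expected, an estimated at least 2.5-fold lower number from compound 2 to compound 3 (0.39 log units; beyond the scatter). For compound 3 the estimated value is 20000 nM, with an expected range of 4000 nM to 60000 nM.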

Compound 3, half-maximal inhibitory concentration: 460 nM
Estimate against measurement, compound 3: 43-fold (1.64 log units) above; the measured number lies below the stated range.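

In this assay, going by these compounds alone, diethylamino on a saturated chain carbon, four bonds along the chain from an aromatic nitrogen, gives the first readable change: an at least 100-fold lower number from compound 2 to compound 3 (2.03 log units; beyond the scatter). Set against the hydroxy-bearing chain, the change reads an at least 100-fold lower number from compound 1 to compound 3 (2.03 log units; beyond the scatter). The step between compound 1 and compound 2 cannot be read, so this chain position first shows a response with compound 3.

As far as these compounds go, both readable steps give only a lower bound on size, since the other compound in each stands at a limit: the limit of > 50000 nM in this assay, at which 2 of the 3 values shown sit. Whether a primary amine, a pyrrolidine or a shorter aminopropyl chain would serve as well remains open.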